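The compounds below may be only part of what the source reports. "The series", "measured", "known", "first", "only" and "open" are said of these compounds alone.

Measured in a functional assay on FM3A cells (Mus musculus) for antiproliferative activity; on this read-out higher numbers stand for weaker inhibition and lower numbers for stronger inhibition:
- compound 1 `COc1cc(C(=O)c2sc(-c3ccc(-c4ccccc4)cc3)cc2N)cc(OC)c1OC`: > 10000 nM
- compound 2 `COc1cc(C(=O)c2sc(-c3ccccc3)cc2N)cc(OC)c1OC`: 13 nM
- compound 3 `COc1cc(C(=O)c2sc(-c3ccc(Cl)c(Cl)c3)cc2N)cc(OC)c1OC`: 400 nM

Compound 1 reads > 10000 nM, which is a limit of the assay and not a number. Compound 2, at 13 nM, holds the lowest number of the three, and compound 3 is nearest at 400 nM.

Compound 4 `COc1cccc(-c2cc(N)c(C(=O)c3cc(OC)c(OC)c(OC)c3)s2)c1` is still to be measured. It differs from compound 2 by methoxy in place of hydrogen on an aromatic carbon, (methoxy in place of hydrogen on an aromatic carbon). Among the compounds with values here, two measured steps bear on this, both changes on the same phenyl. One is a 31-fold higher number from compound 2 to compound 3 (1.49 log units; beyond the scatter). The other is an at least 760-fold lower number from compound 1 to compound 2 (2.88 log units; beyond the scatter), where hydrogen replaces phenyl. In both compounds carrying added groups on this phenyl the number is higher than for compound 2, so a higher number is expected in this assay. With a single methoxy entering, the expected change, a 5.4-fold higher number from compound 2 to compound 4 (0.73 log units; beyond the scatter), is smaller than either measured step. For compound 4 the estimated value is 70 nM, with an expected range of 13 nM to 400 nM.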

Compound 4, half-maximal inhibitory concentration: 36 nM
Beside the measured number, compound 4's estimate is 1.9-fold (0.29 log units) above it; low and high end bracket the measured number.
By their numbers in this assay, from the lowest: compound 2; then compound 4; then compound 3. At a limit, above all of these: compound 1.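

In this assay, the phenyl of compound 2 accepts a single methoxy, meta to a large group, at a modest cost: a 2.8-fold higher number from compound 2 to compound 4 (0.44 log units; beyond the scatter). The earlier substituted compounds showed only large rises, so a group on this phenyl need not bring a large loss. The phenyl-to-3-methoxyphenyl change still gives a higher number, so no added group here has yet improved on compound 2, while replacing 3,4-dichlorophenyl with 3-methoxyphenyl is itself a large step: an 11-fold lower number from compound 3 to compound 4 (1.05 log units; beyond the scatter).

Going by these compounds, it remains open whether a hydroxyl, an amine or a longer ether such as ethoxy at this place would keep the number close to that of compound 4, or lower it. Nothing shown gives a cause for either step.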